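Solubility notes: aryl group exchange on the shared core

The source may report more compounds than this note shows. Statements on the series, on what has been measured and on what is new or still open speak of the compounds shown alone.

Three measured compounds share one core and differ only in the group on the aromatic carbon that carries the pendant ring. In a physicochemical assay for solubility, with a stated time of 18 h, at pH 7.4 (on this read-out higher numbers stand for higher solubility and lower numbers for lower solubility), compound 1 `c1ccc(-c2ccc3c(NCCCNCc4ccco4)ccnc3c2)cc1` gives 32000 nM. Compound 2 `COc1ccc(-c2ccc3c(NCCCNCc4ccco4)ccnc3c2)cc1` gives 32000 nM in this assay. Compound 3 `c1ccc(CCc2ccc3c(NCCCNCc4ccco4)ccnc3c2)cc1` gives 4200 nM in this assay and stands lowest of the three numbers, with compound 1 and compound 2 both beyond the scatter above it. Methoxy in place of hydrogen on an aromatic carbon gave no change at the digits printed from compound 1 to compound 2 (within the scatter). Phenethyl in place of phenyl gave a 7.6-fold lower number from compound 1 to compound 3 (0.88 log units; beyond the scatter), and phenethyl in place of 4-methoxyphenyl gave a 7.6-fold lower number from compound 2 to compound 3 (0.88 log units; beyond the scatter).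

Compound 4 `CN(C)c1cccc(Oc2ccc3c(NCCCNCc4ccco4)ccnc3c2)c1` is not yet measured. Relative to compound 3 the change is 3-(dimethylamino)phenoxy in place of phenethyl on an aromatic carbon. The two steps into compound 3 are the ones that bear on this position; both were modest lowerings, and both came with phenethyl entering. Since phenethyl now leaves and a group with two acceptors enters, the expectation is a step back toward the numbers of compound 1 and compound 2, of about a 3.6-fold higher number from compound 3 to compound 4 (0.55 log units; beyond the scatter) in this assay. Compound 4 is therefore estimated at 15000 nM in this assay, with a range of 4000 nM to 50000 nM.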

Compound 4, solubility: 14500 nM
Compound 4: middle estimate off by 1.0-fold (0.01 log units), on the high side; the range from low to high includes it.
By their numbers in this assay, from the lowest: compound 3; then compound 4; then compounds 1 and 2 (each within the scatter of the next).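

At this position, this assay now shows a level that lies apart from both earlier ones: 3-(dimethylamino)phenoxy in place of phenethyl gave a 3.5-fold higher number from compound 3 to compound 4 (0.54 log units; beyond the scatter). The return toward the aryl compounds is only partial, as 3-(dimethylamino)phenoxy in place of 4-methoxyphenyl gave a 2.2-fold lower number from compound 2 to compound 4 (0.34 log units; beyond the scatter) and the same group in place of phenyl gave a 2.2-fold lower number from compound 1 to compound 4 (0.34 log units; beyond the scatter), so the position no longer reads as two levels, with phenethyl alone set apart from the others. No measurement shown here explains the differences among these groups.

The compounds shown leave open which part of the exchange goes with the step, since the phenethyl-to-3-(dimethylamino)phenoxy change alters the link to the pendant ring and the substituent on that ring together; plain phenoxy and 3-(dimethylamino)phenyl would read these two parts separately. Also open, from the compounds shown here alone, is how this position responds to groups of another kind, such as a morpholine or a carboxylic acid, and whether the order seen here holds on any other core than the shared one.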